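One Fluorine Added to Compound 2

The source may hold more compounds than are shown below. What is called first, only, known or untested is meant among the compounds shown, and "the series" means these compounds.

Measured so far:
compound 1, `CN1CCN(Cc2ccc(Nc3nc(Oc4ccc5ccc(=O)[nH]c5c4)c4sccc4n3)cc2)CC1`: 19300 nM
compound 2, `CN1CCN(c2ccc(Nc3nc(Oc4ccc5ccc(=O)[nH]c5c4)c4sccc4n3)cc2)CC1`: 5780 nM

Both were tested in a functional assay on PC-9 cells (Homo sapiens) for antiproliferative activity, read by MTT assay, with a stated time of 72 h; a lower number here means a stronger inhibitor, a higher number a weaker inhibitor. Among the measured compounds shown here, compound 2 has the lower of the two numbers, and the only step available, a 3.3-fold lower number from compound 1 to compound 2 (0.52 log units; beyond the scatter), is the sole guide to how changes on this scaffold play out.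

Compound 3, `CN1CCN(c2ccc(Nc3nc(Oc4ccc5ccc(=O)[nH]c5c4)c4sccc4n3)cc2F)CC1`, is the next compound. It differs from compound 2 by fluoro in place of hydrogen on an aromatic carbon. For the measured compounds named here, the one measured step concerns the link between the 4-methylpiperazin-1-yl group and its ring, not a fluorine, so it does not bear on this change; no measured pair shows what a fluoro in place of hydrogen does here. With nothing to point in either direction, the expected step from compound 2 to compound 3 is a 1.3-fold lower number from compound 2 to compound 3 (0.11 log units; within the scatter), that is, no change beyond the scatter. Compound 3 is therefore estimated at 4500 nM, within a range of 1500 nM to 14000 nM.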

Compound 3, half-maximal inhibitory concentration: > 50000 nM
Compound 3 gave a limit, no number; the forecaster's own chance of this, stated with the estimate: 5%; at least 11-fold (1.04 log units) between middle value and limit.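

In this assay compound 3 reads > 50000 nM, which is a limit of the assay and not a number. This shows that the aromatic carbon ortho to the 4-methylpiperazin-1-yl group does not tolerate every small change: a single fluoro in place of hydrogen, only 1 heavy atom, gives an at least 8.6-fold higher number from compound 2 to compound 3 (0.93 log units; beyond the scatter), so even the smallest swap here can cost much of the activity. The true size of this step stays unknown, and only its lower bound can be read, as the result rests on a limit: the limit of > 50000 nM in this assay, at which 1 of the 3 values shown sits.

From the compounds shown here alone, it remains open whether this loss is specific to fluoro or would follow any group on this carbon, which a chlorine, a methyl or a methoxy group in the same place could settle. Going by these compounds, it is also open whether a fluoro on another carbon of this ring would behave in the same way.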